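Amide aryl swaps on a chromone acetamide series

A few compounds are considered here, and "the series" means these few. Any claim that something is new, unique, unknown or untested is made for them only; others in the source may bear on it.

Measured so far:
compound 1 `CCCc1ccc(C(=O)Nc2cccc(NC(=O)COc3ccc4c(=O)ccoc4c3)c2)cc1`, 143 nM
compound 2 `COc1ccc(C(=O)Nc2cccc(NC(=O)COc3ccc4c(=O)ccoc4c3)c2)cc1`, 18 nM
compound 3 `Cc1cc(C(=O)Nc2cccc(NC(=O)COc3ccc4c(=O)ccoc4c3)c2)no1`, 68 nM

In an assay on isolated protein for inhibition of Rho-associated protein kinase 1 (Homo sapiens), read by scintillation counting, radiometric assay and 33P incorporation, with a stated time of 40 min, in the presence of a further agent that is not named here (on this read-out lower numbers stand for stronger inhibition and higher numbers for weaker inhibition), compound 3 sits second highest of the three numbers, a 2.1-fold lower number from compound 1 to compound 3 (0.32 log units; beyond the scatter) and a 3.8-fold higher number from compound 2 to compound 3 (0.58 log units; beyond the scatter). The next compound is compound 4 `Nc1cccc(C(=O)Nc2cccc(NC(=O)COc3ccc4c(=O)ccoc4c3)c2)c1`; the change is 3-aminophenyl in place of 5-methyl-1,2-oxazol-3-yl on a carbonyl carbon. Among the measured compounds shown here, two steps bear on it: a 3.8-fold higher number from compound 2 to compound 3 (0.58 log units; beyond the scatter) shows that a six-membered carbon ring on this carbonyl can give a lower number than the five-membered ring, while a 2.1-fold lower number from compound 1 to compound 3 (0.32 log units; beyond the scatter) shows the opposite; the amino-bearing ring has no measured counterpart. A small lowering is expected, a 1.7-fold lower number from compound 3 to compound 4 (0.23 log units; within the scatter), within or near the scatter. Compound 4 is therefore estimated at 40 nM, between 12 nM and 130 nM.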

Compound 4, half-maximal inhibitory concentration: 670 nM
Compound 4: middle estimate off by 17-fold (1.22 log units), on the low side; measured number above the stated range.
By their numbers in this assay, from the lowest: compound 2; then compound 3; then compound 1; then compound 4.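

In this assay, 3-aminophenyl on this carbonyl carbon gives the highest number of the four compounds: a 9.9-fold higher number from compound 3 to compound 4 (0.99 log units; beyond the scatter), a 4.7-fold higher number from compound 1 to compound 4 (0.67 log units; beyond the scatter) and a 37-fold higher number from compound 2 to compound 4 (1.57 log units; beyond the scatter). A six-membered aromatic ring of carbon only at this place therefore does not by itself give a lower number than 5-methyl-1,2-oxazol-3-yl, and the outcome depends on what the ring carries. Nothing available bears on the cause of this rise.

Plain phenyl and 3-methoxyphenyl stand outside the compounds shown, so it remains open whether the amine itself or the substituent's place on the ring accounts for the step.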